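Methoxy removal on the imidazole-linked aryl group

The source may hold more compounds than are shown below. What is called first, only, known or untested is meant among the compounds shown, and "the series" means these compounds.

For the measured compounds named here, compound 2 `COc1ccc(-c2cn(-c3ccnc4c3c(C(C)C)nn4-c3ccc(C(N)=O)c(N[C@H]4CC[C@H](O)CC4)c3)cn2)cc1` gives 256 nM in a functional assay on SK-BR-3 cells (Homo sapiens) for inhibition, read by CellTiter-Glo, with a stated time of 72 h (a higher number here means a weaker inhibitor, a lower number a stronger inhibitor), the only numerical value so far. Compound 1 `CC(C)c1nn(-c2ccc(C(N)=O)c(N[C@H]3CC[C@H](O)CC3)c2)c2nccc(-c3ccccc3)c12` reaches only the assay limit of > 10000 nM in this assay. Compound 3 `CC(C)c1nn(-c2ccc(C(N)=O)c(N[C@H]3CC[C@H](O)CC3)c2)c2nccc(-n3cnc(-c4ccccc4)c3)c12` differs from compound 2 by hydrogen in place of methoxy on an aromatic carbon. Going by the values given here, no measured step of this kind exists in the set, so the direction is open; a small weakening, or nothing beyond the usual scatter, is expected. For compound 3 the estimate in this assay is 400 nM, with a range of 150 nM to 1200 nM. This corresponds to an expected step of a 1.6-fold higher number from compound 2 to compound 3 (0.19 log units; within the scatter).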

Compound 3, half-maximal inhibitory concentration: 276 nM
Compound 3: the middle estimate sits 1.4-fold (0.16 log units) above what was measured; the measured number falls inside the stated range.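

In this assay, the change from 4-methoxyphenyl to phenyl leaves the number within the scatter: a 1.1-fold higher number from compound 2 to compound 3 (0.03 log units; within the scatter). The large step lies with 4-phenyl-1H-imidazol-1-yl in place of phenyl on an aromatic carbon: an at least 36-fold lower number from compound 1 to compound 3 (1.55 log units; beyond the scatter). Compound 1 stands at > 10000 nM, which is a limit of the assay and not a number, so this step has no exact size.

Open, going by these compounds, is whether an amine or a carboxylic acid on this aromatic carbon would shift the number as little as methoxy does. Also open, on these data alone, is what a methyl group in place of the terminal phenyl would give.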